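The source may hold more compounds than are shown below. What is called first, only, known or untested is meant among the compounds shown, and "the series" means these compounds.

Series notes. Compound 2 `Nc1ncnc2c1ncn2[C@@H]1CO[C@H](COS(=O)(=O)NC(=O)[C@@H]2CCCN2)[C@@H](O)C1` is the simplest member; in a functional assay on PBMC cells (Homo sapiens) for inhibition (a higher number here means a weaker inhibitor, a lower number a stronger inhibitor), compound 2 gives 2800 nM. Compound 1 `N=C(N)NCCC[C@H](N)C(=O)NS(=O)(=O)OC[C@H]1OC[C@@H](n2cnc3c(N)ncnc32)C[C@@H]1O` differs from compound 2 at the acyl part of the sulfamoyl linkage: a group of 9 heavy atoms (5 carbon, 4 nitrogen; no ring) in place of a group of 5 heavy atoms (4 carbon, 1 nitrogen; one five-membered non-aromatic ring with 1 hetero atom), on a carbonyl carbon. That exchange moved the read-out a 4.7-fold lower number from compound 2 to compound 1 (0.67 log units; beyond the scatter), and in this assay compound 1 gives 600 nM. Compound 3 `Nc1ncnc2c1ncn2[C@@H]1CO[C@H](COS(=O)(=O)NC(=O)[C@@H]2CCCN2)[C@@H](O)[C@H]1O` keeps the acyl part of compound 2 but carries a changed core: hydroxy in place of hydrogen on a saturated ring carbon. This gave a 3.7-fold lower number from compound 2 to compound 3 (0.57 log units; beyond the scatter), and in this assay compound 3 gives 750 nM.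

Compound 4 `N=C(N)NCCC[C@H](N)C(=O)NS(=O)(=O)OC[C@H]1OC[C@@H](n2cnc3c(N)ncnc32)[C@H](O)[C@@H]1O` has not yet been run in this assay. It stands to compound 3 as compound 1 stands to compound 2: a group of 9 heavy atoms (5 carbon, 4 nitrogen; no ring) in place of a group of 5 heavy atoms (4 carbon, 1 nitrogen; one five-membered non-aromatic ring with 1 hetero atom), on a carbonyl carbon. The place line for this exchange reads the same, word for word, as the place line for the exchange from compound 2 to compound 1, so the two are the same change, made once on the core of compound 2 and once on the core of compound 3, whose difference is given by hydroxy in place of hydrogen on a saturated ring carbon. Within the data shown here, the single precedent is the step from compound 2 to compound 1, a 4.7-fold lower number from compound 2 to compound 1 (0.67 log units; beyond the scatter), which lies beyond the scatter. On that basis a step of similar direction and of roughly similar size is expected for compound 4, a 3.8-fold lower number from compound 3 to compound 4 (0.57 log units; beyond the scatter). Among the measured compounds shown here, only one earlier instance of the change exists, and the two core changes are each seen once, so this expectation is held loosely. The estimate for compound 4 in this assay is 200 nM, expected to fall between 70 nM and 600 nM.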

Compound 4, half-maximal inhibitory concentration: 600 nM
Estimate against measurement, compound 4: 3.0-fold (0.48 log units) below; low and high end bracket the measured number.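

In this assay, the open-chain acyl group in place of pyrrolidin-2-yl on the carbonyl carbon gives a 1.3-fold lower number from compound 3 to compound 4 (0.10 log units; within the scatter), so the clear step seen on the core without the extra hydroxy does not carry over to the hydroxylated core: the same change on two cores in this assay, a 4.7-fold lower number (0.67 log units; beyond the scatter) from compound 2 to compound 1 and a 1.3-fold lower number (0.10 log units; within the scatter) from compound 3 to compound 4, 3.7-fold (0.57 log units) apart, beyond the scatter of two such steps

Read the other way, hydroxy in place of hydrogen on a saturated ring carbon gives no change at the digits printed from compound 1 to compound 4 (within the scatter), so this change also depends on its partner, here the acyl group: the same change on two cores in this assay, a 3.7-fold lower number (0.57 log units; beyond the scatter) from compound 2 to compound 3 and no change at the digits printed (within the scatter) from compound 1 to compound 4, 3.7-fold (0.57 log units) apart, beyond the scatter of two such steps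

Each change is seen only as a single pair of steps, which shows that the two changes do not add within these four compounds but gives neither a reason for this nor a rule for how either change would behave on a further core.

Still open, from the compounds shown here alone, is whether the same dependence appears with other acyl groups, such as a chain ending in a primary amine, a longer chain or one ending in a carboxylic acid. Also open, going by these compounds, is whether a methoxy or a fluorine at the ring carbon that carries the added hydroxy would behave as the hydroxy does.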